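The source may report more compounds than this note shows. Statements on the series, on what has been measured and on what is new or still open speak of the compounds shown alone.

Measured compounds:
Compound 1 `O=C(CSc1nc2ccccc2s1)N/N=C/c1ccc(Oc2ccc(Cl)cc2)cc1` gives 5.6 in a physicochemical assay for lipophilicity, in phosphate buffer, measured as octanol-water partition, with a stated time of 24 h; on this read-out higher numbers stand for higher lipophilicity and lower numbers for lower lipophilicity.
Compound 2 `Fc1ccc(Oc2ccc(/C=N/Nc3nc4ccccc4s3)cc2)cc1` gives 5 in this assay.
Compound 3 `Clc1ccc(Oc2ccc(/C=N/Nc3nc4ccccc4s3)cc2)cc1` gives 5.6 in this assay.

Compound 1 stands level with compound 3 at the digits shown, and the two share the highest numbers of the three; compound 2 lies lower, beyond the scatter. Compound 4 `O=C(CSc1nc2ccccc2s1)N/N=C/c1ccc(Oc2ccc(Br)cc2)cc1` differs from compound 1 by bromo in place of chloro on an aromatic carbon. For the measured compounds named here, no measured pair shows this exact change. Going by the values given here, the only halogen exchange among the measured compounds is a number 0.60 log units higher from compound 2 to compound 3 (beyond the scatter), a modest rise. For compound 4 a step of a number 0.20 log units higher from compound 1 to compound 4 (within the scatter) in this assay is expected, no larger than that one and most likely within the scatter. Compound 4 is therefore estimated at 5.8, with a range from 5.5 to 6.1.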

Compound 4, partition coefficient: 5.7
For compound 4 the middle estimate is 0.10 log units above the measured one; measured number inside the range.
By their numbers in this assay, from the lowest: compound 2; then compounds 1, 3 and 4 (each within the scatter of the next).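

In this assay, the change from 4-chlorophenoxy to 4-bromophenoxy gives a number 0.10 log units higher from compound 1 to compound 4 (within the scatter), so the two halogens are level at this position on the core of compound 1. For the compounds shown here, the only earlier halogen exchange, chloro in place of fluoro on a different core, gave a number 0.60 log units higher from compound 2 to compound 3 (beyond the scatter), and so a step at this position need not lie beyond the scatter. Nothing at hand accounts for either step. On these data alone, the effect of an amine or a carboxylic acid at this position remains open. So does the size of the step for bromo in place of chloro on the core of compound 3.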